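Removal of the aryl methyl: compound 1 to compound 4

A few compounds are considered here, and "the series" means these few. Any claim that something is new, unique, unknown or untested is made for them only; others in the source may bear on it.

Measured so far:
compound 1 `Cc1ccccc1S(=O)(=O)c1ccc(CNC(=O)c2cc3cnccc3[nH]2)cc1` — 13 nM in a functional assay on A2780 cells (Homo sapiens) for inhibition, read by sulforhodamine B assay, with a stated time of 72 h; on this read-out lower numbers stand for stronger inhibition and higher numbers for weaker inhibition
compound 2 `O=C(NCc1ccc(S(=O)(=O)c2cccc(C(F)(F)F)c2)cc1)c1cc2ccncc2o1` — 3 nM
compound 3 `O=C(NCc1ccc(S(=O)(=O)c2cccc(C(F)(F)F)c2)cc1)c1cnc2nccn2c1` — 2 nM

On these numbers compound 1 stands highest of the three, with compound 2 and compound 3 both beyond the scatter below it. Compound 4 `O=C(NCc1ccc(S(=O)(=O)c2ccccc2)cc1)c1cc2cnccc2[nH]1` keeps the core of compound 1 and differs only in hydrogen in place of methyl on an aromatic carbon. Going by the values given here, no measured step touches this position. Among the compounds with values here, the single measured step, a 1.5-fold lower number from compound 2 to compound 3 (0.18 log units; within the scatter), changes the group on the carbonyl carbon and lies within the scatter, which gives no guidance on the methyl. With nothing that bears on the change, the expected step of a 1.5-fold higher number from compound 1 to compound 4 (0.19 log units; within the scatter) is none beyond the scatter, and the range is set wide on both sides. Compound 4 is therefore estimated at 20 nM, between 7 nM and 60 nM.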

Compound 4, half-maximal inhibitory concentration: 18 nM
Compound 4: middle estimate off by 1.1-fold (0.05 log units), on the high side; low and high end bracket the measured number.
By their numbers in this assay, from the lowest: compounds 3 and 2 (each within the scatter of the next); then compounds 1 and 4 (each within the scatter of the next).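

In this assay, hydrogen in place of methyl on the aromatic carbon ortho to a large group gives a 1.4-fold higher number from compound 1 to compound 4 (0.14 log units; within the scatter). On the shared core, 2-methylphenyl and phenyl therefore cannot be told apart on this read-out, and the methyl is not required for a value in this range. No data on hand bear on why the two compounds read alike.

Open, on these data alone, is whether a different group at this place, such as methoxy, chlorine or an amine, would also read alike. Two compounds cannot show how far this tolerance extends.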